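Lengthening the Chain of Compound 2

The source may hold more compounds than are shown below. What is called first, only, known or untested is meant among the compounds shown, and "the series" means these compounds.

In a functional assay on the whole organism with Scenedesmus acutus as the target (on this read-out lower numbers stand for stronger inhibition and higher numbers for weaker inhibition), compound 1 `COC(=O)c1cc(N2C(=O)C3=C(CCCC3)C2=O)ccc1Cl` gives 2000 nM, and compound 2 `CCCCOC(=O)c1cc(N2C(=O)C3=C(CCCC3)C2=O)ccc1Cl` gives 3550 nM. Among the measured compounds shown here, these two values lie within the scatter of each other, so compound 2 stands level with compound 1 on the numbers so far. Compound 3 `CCCCCOC(=O)c1cc(N2C(=O)C3=C(CCCC3)C2=O)ccc1Cl` has yet to be measured. Its difference from compound 2 is methyl in place of hydrogen on a saturated chain carbon, four bonds along the chain from an oxygen next to a carbonyl group, on a saturated chain carbon, four bonds along the chain from an oxygen next to a carbonyl group. For the measured compounds named here, one measured step bears on this change, a lengthening of the same chain, a 1.8-fold higher number from compound 1 to compound 2 (0.25 log units; within the scatter). Going by the values given here, that step stayed within the scatter, and no other step is available as a guide. In this assay, therefore, no change beyond the scatter is expected, with any drift more likely toward a slightly higher number. The expected step is a 1.1-fold higher number from compound 2 to compound 3 (0.05 log units; within the scatter). For compound 3 the estimated value is 4000 nM, with an expected range of 1800 nM to 9000 nM.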

Compound 3, half-maximal inhibitory concentration: 9330 nM
Beside the measured number, compound 3's estimate is 2.3-fold (0.37 log units) below it; the whole stated range lies below it.
By their numbers in this assay, from the lowest: compounds 1 and 2 (each within the scatter of the next); then compound 3.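

In this assay methyl in place of hydrogen on a saturated chain carbon, four bonds along the chain from an oxygen next to a carbonyl group, gives a 2.6-fold higher number from compound 2 to compound 3 (0.42 log units; beyond the scatter) and so passes beyond the scatter, which the earlier lengthening of this chain did not. Counted from the shortest chain shown, the lengthening gives a 4.7-fold higher number from compound 1 to compound 3 (0.67 log units; beyond the scatter) and so the longest chain shown is the weakest inhibitor of the three. Nothing available gives a measured reason for this loss of inhibition.

On these data alone, whether a still longer chain such as hexyl or octyl would weaken inhibition further remains open. So does how a branched chain, or a chain ending in a hydroxyl or a carboxylic acid, would compare.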